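Cytotoxicity limits in the series and the step to compound 4

The source may hold more compounds than are shown below. What is called first, only, known or untested is meant among the compounds shown, and "the series" means these compounds.

Compound 1 `Nc1nc(Cl)c(-c2cccs2)c(N[C@@H]2C[C@H](CO)[C@@H](O)[C@H]2O)n1` in an ADME assay on cells (Homo sapiens) for cytotoxicity, read by polymerase chain reaction, with a stated time of 3 days (a lower number here means that less compound is tolerated, a higher number that more compound is tolerated), gives a limit of the assay, > 25000 nM.
Compound 2 `Nc1nc(Cl)c(-c2cc3ccccc3s2)c(N[C@@H]2C[C@H](CO)[C@@H](O)[C@H]2O)n1` in this assay gives a limit of the assay, > 25000 nM.
Compound 3 `CNc1nc(C)c(-c2nc3ccccc3s2)c(N[C@@H]2C[C@H](CO)[C@@H](O)[C@H]2O)n1` in this assay gives a limit of the assay, > 25000 nM.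

Compound 3 therefore stands at the limit, which is where every measured value in this set sits (the limit of > 25000 nM in this assay, at which 3 of the 3 values shown sit). For the measured compounds named here, the single measured step, a step that the two limits leave unreadable from compound 1 to compound 2, runs between two limits and offers no readable size.

Compound 4 `Cc1nc(NCC(C)C)nc(N[C@@H]2C[C@H](CO)[C@@H](O)[C@H]2O)c1-c1nc2ccccc2s1` differs from compound 3 by isopropyl in place of hydrogen on a saturated chain carbon bound to a nitrogen on an aromatic ring. Going by the values given here, no measured step touches this change, and the three values give only a limit as background. The step that the limit leaves unreadable from compound 3 to compound 4 is expected to be none beyond the scatter. Compound 4 is estimated at 30000 nM in this assay, with a range from 10000 nM to 100000 nM, most likely again reported as a limit.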

Compound 4, half-maximal cytotoxic concentration: 10000 nM
For compound 4 the middle estimate is 3.0-fold (0.48 log units) above the measured one, and the stated range covers the measured number.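

For the compounds shown here, compound 4 is the first in the set with a number rather than a limit, and in this assay this gives the first readable step, an at least 2.5-fold lower number from compound 3 to compound 4 (0.39 log units; beyond the scatter). Here less compound is tolerated with isobutylamino in place of methylamino, so this position can affect the read-out. The other compounds remain at the limit: the limit of > 25000 nM in this assay, at which 3 of the 4 values shown sit.

From the compounds shown here alone, compound 3 carries only a limit of the assay, > 25000 nM, so the full size of the step stays open. Also open, going by these compounds, is whether a straight butyl chain or a terminal amine at this position would lower the number further or return it to the limit.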